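Trifluoromethoxy for Trifluoromethyl: A Small Step Expected

The source may report more compounds than this note shows. Statements on the series, on what has been measured and on what is new or still open speak of the compounds shown alone.

In a functional assay on LNCaP cells (Homo sapiens) for antiproliferative activity, read by propidium iodide staining, with a stated time of 96 h (a lower number here means a stronger inhibitor, a higher number a weaker inhibitor), compound 1 (`CC(O)(CSc1ccc(F)cc1)C(=O)Nc1cccc(S(F)(F)(F)(F)F)c1`) gives 26900 nM as its value, while compound 2 (`CC(O)(CSc1ccccc1C(F)(F)F)C(=O)Nc1cccc(S(F)(F)(F)(F)F)c1`) gives 12300 nM and holds the lower of the two numbers. Compound 3 (`CC(O)(CSc1ccccc1OC(F)(F)F)C(=O)Nc1cccc(S(F)(F)(F)(F)F)c1`) differs from compound 2 by trifluoromethoxy in place of trifluoromethyl on an aromatic carbon, ortho to a large group (trifluoromethoxy in place of trifluoromethyl on an aromatic carbon). Among the measured compounds shown here, no measured step tests this exchange directly. For the measured compounds named here, the only measured step (a 2.2-fold lower number from compound 1 to compound 2 (0.34 log units; beyond the scatter)) was modest and came with a different exchange, 2-(trifluoromethyl)phenyl in place of 4-fluorophenyl on a sulfur. A change of similar or smaller size is therefore expected in this assay, probably not beyond the scatter and with neither direction favoured. The expected step (a 1.0-fold lower number from compound 2 to compound 3 (0.01 log units; within the scatter)) is small in this estimate. Compound 3 is estimated at 12000 nM with an expected range from 5000 nM to 27000 nM overall.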

Compound 3, half-maximal inhibitory concentration: 10000 nM
Beside the measured number, compound 3's estimate is 1.2-fold (0.08 log units) above it, and the stated range covers the measured number.
By their numbers in this assay, from the lowest: compounds 3 and 2 (each within the scatter of the next); then compound 1.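

At this place, on an aromatic carbon ortho to a large group, the exchange of trifluoromethyl for trifluoromethoxy now has a direct reading: in this assay it gives a 1.2-fold lower number from compound 2 to compound 3 (0.09 log units; within the scatter) and so leaves the two compounds indistinguishable. The oxygen atom that trifluoromethoxy adds, and the hydrogen-bond acceptor counted with it, therefore bring no difference that this read-out can separate from the scatter, a finding that holds for this one pair only. No measurement shown here offers an explanation for why the two groups read alike.

On these data alone, whether an amine or a carboxylic acid at this place would stay within the scatter of compound 2 remains open. As far as these compounds go, it is also open whether the same exchange would read alike at any other place on the ring.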